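Methoxy for Fluoro: Expected Cytotoxicity of Compound 4

This account rests on a few compounds, and the source may have more. Where it says the series, first, only, none or still open, it means among the compounds named here.

Three compounds have been measured in a functional assay on KB cells (Homo sapiens) for cytotoxicity, read by MTT assay, with a stated time of 72 h; a higher number here means a weaker inhibitor, a lower number a stronger inhibitor:

Compound 1, `O=C(NC(=S)NNc1ncnc2ccccc12)c1ccccc1F`, gives 2510 nM.
Compound 2, `COc1cc2ncnc(NNC(=S)NC(=O)c3ccccc3F)c2cc1OC`, gives 4070 nM.
Compound 3, `COc1cc2ncnc(NNC(=S)NC(=O)c3ccccc3OC)c2cc1OC`, gives 3850 nM.

All three numbers lie within the scatter of one another, so none can be called stronger or weaker than the rest. Compound 1 and compound 2 differ in their cores; the difference between the two cores is not broken down here. Compound 2 and compound 3 differ in one place only, (methoxy in place of fluoro on an aromatic carbon), and that change produced a 1.1-fold lower number from compound 2 to compound 3 (0.02 log units; within the scatter).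

Compound 4, `COc1ccccc1C(=O)NC(=S)NNc1ncnc2ccccc12`, is not yet measured. Going by the values given here, it differs from compound 1 by methoxy in place of fluoro on an aromatic carbon, which is the same change, at the same kind of place, as the one from compound 2 to compound 3. Among the compounds with values here, the only guide is that single step, seen on a different core. On that basis, the step from compound 1 to compound 4 is expected to be about a 1.0-fold lower number from compound 1 to compound 4 (0.02 log units; within the scatter), because the step of a 1.1-fold lower number from compound 2 to compound 3 (0.02 log units; within the scatter) stayed within the scatter. Compound 4 is therefore estimated at 2400 nM, with a likely range from 1100 nM to 5200 nM.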

Compound 4, half-maximal inhibitory concentration: > 50000 nM
Compound 4 ended at the assay's limit (the forecaster's own chance of this, stated with the estimate: 3%); middle value at least 20-fold (1.31 log units) from the limit.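

In this assay, exchanging 2-fluorophenyl for 2-methoxyphenyl on the core of compound 1 gave an at least 19-fold higher number from compound 1 to compound 4 (1.29 log units; beyond the scatter). On these data alone, the value of compound 4, > 50000 nM, is a limit of the assay and not a number, so the full size of this step remains unknown. This change therefore did not carry over unchanged from one core to the other, although two cores alone cannot show which feature of the core matters or how the change would behave on any further core: the same change on two cores in this assay, a 1.1-fold lower number (0.02 log units; within the scatter) from compound 2 to compound 3 and an at least 19-fold higher number (1.29 log units; beyond the scatter) from compound 1 to compound 4, at least 21-fold (1.32 log units) apart, beyond the scatter of two such steps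

As far as these compounds go, only fluoro and methoxy appear at this place, so it remains open how chloro, hydroxy or ethoxy would behave on either core. Also open is which part of the difference between the core of compound 1 and the core of compound 2 separates the two outcomes, since the compounds shown change that core only as a whole.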